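The compounds below may be only part of what the source reports. "The series", "measured", "known", "first", "only" and "open" are said of these compounds alone.

Working notes on the series. Compound 1 `c1ccc(C(c2ccco2)N2CCN(c3ncnc4c3cnn4-c3ccccc3)CC2)cc1` and compound 2 `Cc1ccsc1C(c1ccccc1)N1CCN(c2ncnc3c2cnn3-c2ccccc2)CC1` share one core and differ only at the saturated chain carbon bound to an amine nitrogen in a ring and an aromatic carbon. In a functional assay on cells (Rhabdomyosarcoma cell, Homo sapiens) for cytotoxicity (a higher number here means a weaker inhibitor, a lower number a stronger inhibitor), compound 1 returns only the assay limit, > 25000 nM. In this assay compound 2 also returns only the assay limit, > 25000 nM. Among the measured compounds shown here, the single measured step, a step that the two limits leave unreadable from compound 1 to compound 2, is therefore unreadable in size, both values sitting at the limit of > 25000 nM in this assay, at which 2 of the 2 values shown sit. Compound 3 `N#Cc1ccc(C(c2ccccc2)N2CCN(c3ncnc4c3cnn4-c3ccccc3)CC2)cc1` awaits measurement and differs from compound 2 thus: 4-cyanophenyl in place of 3-methylthiophen-2-yl on a saturated chain carbon bound to an amine nitrogen in a ring and an aromatic carbon. For the measured compounds named here, the one step at this position gives no readable size, so no direction beyond the scatter can be set for compound 3 in this assay. Compound 3 is expected to stay at or near the limit, estimated at 30000 nM with a range of 10000 nM to 100000 nM. The expected step is a step that the limit leaves unreadable from compound 2 to compound 3.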

Compound 3, half-maximal inhibitory concentration: > 25000 nM
Compound 3: no number, only a limit; the forecaster's own chance of this, stated with the estimate: 80%; the middle value does not contradict the limit.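

In this assay compound 3 gives > 25000 nM, a limit and not a number. No step among compound 1, compound 2 and compound 3 can be read: the limit of > 25000 nM in this assay, at which 3 of the 3 values shown sit.

The compounds shown leave open whether any group at this saturated chain carbon gives a measurable half-maximal inhibitory concentration.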